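Trimming the Sulfonyl Aryl Group Down to Methyl

The source may report more compounds than this note shows. Statements on the series, on what has been measured and on what is new or still open speak of the compounds shown alone.

Compound 3, `CCN(CC)c1ccc2cc(C(=O)c3ccc(N4CCN(S(=O)(=O)c5ccc(Br)c(F)c5)CC4)cc3)oc2c1`, is one of three measured analogues that share a core and differ only in the group on the sulfonyl sulfur. In a functional assay on HeLa cells (Homo sapiens) for cytotoxicity, read by MTT assay, with a stated time of 48 h (a lower number here means a stronger inhibitor, a higher number a weaker inhibitor), compound 3 gives 20700 nM. Compound 2, `CCN(CC)c1ccc2cc(C(=O)c3ccc(N4CCN(S(=O)(=O)c5ccc(C(F)(F)F)cc5)CC4)cc3)oc2c1`, gives 9720 nM in this assay. Compound 1, `CCN(CC)c1ccc2cc(C(=O)c3ccc(N4CCN(S(=O)(=O)c5ccc(Br)cc5)CC4)cc3)oc2c1`, reaches only a limit of this assay, > 40000 nM, so its number is not known beyond that. Of the two plain numbers, compound 3 has the higher one, and a 2.1-fold higher number from compound 2 to compound 3 (0.33 log units; beyond the scatter). The other measured steps are an at least 4.1-fold lower number from compound 1 to compound 2 (0.61 log units; beyond the scatter) and an at least 1.9-fold lower number from compound 1 to compound 3 (0.28 log units; that floor lies within the scatter); both start from the limit of compound 1 (the limit of > 40000 nM in this assay, at which 1 of the 3 values shown sits), so only a floor is known for them.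

Compound 4, `CCN(CC)c1ccc2cc(C(=O)c3ccc(N4CCN(S(C)(=O)=O)CC4)cc3)oc2c1`, differs from compound 3 in one place: methyl in place of 4-bromo-3-fluorophenyl on a sulfonyl sulfur. Within the data shown here, none of the measured steps removes the aromatic ring from the sulfonyl sulfur; the closest, from compound 2 to compound 3, only exchanges one substituted ring for another and was modest. Among the measured compounds shown here, with no measured step of this kind, and with all three measured compounds weak in this assay, the expectation for compound 4 is a number no lower than that of compound 3 and possibly beyond the limit of this assay. The estimate for compound 4 in this assay is 35000 nM, with a range from 12000 nM to 100000 nM, which means an expected step of a 1.7-fold higher number from compound 3 to compound 4 (0.23 log units; within the scatter).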

Compound 4, half-maximal inhibitory concentration: > 40000 nM
Compound 4: no number, only a limit; the forecaster's own chance of this, stated with the estimate: 45%; middle value at least 1.1-fold (0.05 log units) away from the limit.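

Putting methyl on the sulfonyl sulfur removes the aromatic ring there altogether, and in this assay compound 4 yields a limit rather than a number, joining compound 1: the limit of > 40000 nM in this assay, at which 2 of the 4 values shown sit. Against the ring carrying trifluoromethyl, this change gives an at least 4.1-fold higher number from compound 2 to compound 4 (0.61 log units; beyond the scatter), so at least one ring on this sulfur outperforms methyl, while against the 4-bromo-3-fluorophenyl ring it gives an at least 1.9-fold higher number from compound 3 to compound 4 (0.28 log units; that floor lies within the scatter), so no real difference can be claimed for that pair. Compound 1 keeps an aromatic ring and still sits at a limit, so a ring alone is not enough, and the step between compound 1 and compound 4 cannot be read.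

On these data alone, how far compound 4 lies past its limit remains unknown, so the full size of the change from either ring is also unknown. The compounds shown also leave open whether a longer chain such as butyl, or an aromatic ring bearing an amine or a carboxylic acid, would give a lower number than methyl or the rings tested here.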